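Aryl sulfonate series: homologation on the urea nitrogen

A few compounds are considered here, and "the series" means these few. Any claim that something is new, unique, unknown or untested is made for them only; others in the source may bear on it.

Measured so far:
compound 1, `CC(C)C(=O)Nc1ccc(S(=O)(=O)Oc2ccccc2C(C)C)cc1`, 4900 nM
compound 2, `CC(C)c1ccccc1OS(=O)(=O)c1ccc(NC(=O)NC2CCCC2)cc1`, 3900 nM

Both numbers come from a functional assay on HT-1080 cells (Homo sapiens) for antiproliferative activity, read by sulforhodamine B assay, with a stated time of 48 h; on this read-out lower numbers stand for stronger inhibition and higher numbers for weaker inhibition. Among the measured compounds shown here, compound 2 gives the lowest of the two numbers in this assay, but its nearest neighbour is compound 1, and the sole step between them, a 1.3-fold lower number from compound 1 to compound 2 (0.10 log units; within the scatter), stays within the scatter, so no order between the two can be read.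

Compound 3 is `CC(C)c1ccccc1OS(=O)(=O)c1ccc(NC(=O)NCC2CCCC2)cc1`, not yet measured. It differs from compound 2 by one change: cyclopentylmethyl in place of cyclopentyl on an amide-type nitrogen. For the measured compounds named here, no measured step touches this position; the one step known, from compound 1 to compound 2, concerns the carbonyl substituent and was within the scatter. The series therefore gives no ground to expect a step beyond the scatter in this assay for this homologation, in either direction.

The estimate for compound 3 in this assay is 3500 nM, with a range from 1500 nM to 8000 nM. That estimate means a step of a 1.1-fold lower number from compound 2 to compound 3 (0.05 log units; within the scatter), which is expected to fall within the scatter.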

Compound 3, half-maximal inhibitory concentration: 6000 nM
For compound 3 the middle estimate is 1.7-fold (0.23 log units) below the measured one; the measured number falls inside the stated range.
By their numbers in this assay, from the lowest: compounds 2, 1 and 3 (each within the scatter of the next).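

In this assay, among the compounds shown here, the amide-type nitrogen now has a first measured step of its own: cyclopentylmethyl in place of cyclopentyl gives a 1.5-fold higher number from compound 2 to compound 3 (0.19 log units; within the scatter) and so leaves no order to be read between the two compounds. The wider change on the carbonyl carbon, (cyclopentylmethyl)amino in place of isopropyl, gives a 1.2-fold higher number from compound 1 to compound 3 (0.09 log units; within the scatter) and is likewise unresolved, so neither the urea with the added methylene nor the simple isopropyl amide separates from the others, and all three compounds remain a single group on this read-out. No other data bear on this result, and nothing here speaks to any reason for it.

The groups shown on this nitrogen are only cyclopentyl and cyclopentylmethyl, both carbon-only rings with no hydrogen-bond donors or acceptors, so it remains open whether any change at this position can produce a step beyond the scatter. A longer chain such as 2-cyclopentylethyl, a piperidine ring carrying an amine, or a carboxylic acid on the cyclopentyl ring would test that in this assay by reaching outside this narrow set of groups.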